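The compounds below may be only part of what the source reports. "The series", "measured", "known", "first", "only" and "open" are said of these compounds alone.

In a functional assay on CCRF-CEM cells (Homo sapiens) for antiproliferative activity (on this read-out higher numbers stand for weaker inhibition and lower numbers for stronger inhibition), compound 3 (`COc1cc(C(=O)c2sc(-c3cccs3)cc2N)cc(OC)c1OC`) gives 9.4 nM and stands lowest of the three measured numbers, ahead of compound 1 (`COc1ccc(-c2cc(N)c(C(=O)c3cc(OC)c(OC)c(OC)c3)s2)cc1OC`) at 20 nM and compound 2 (`COc1cc(C(=O)c2sc(-c3ccncc3)cc2N)cc(OC)c1OC`) at 110 nM on this scale. Compound 4 (`COc1cc(C(=O)c2sc(-c3ccc(C(F)(F)F)cc3)cc2N)cc(OC)c1OC`) carries 4-(trifluoromethyl)phenyl in place of thiophen-2-yl on an aromatic carbon. Two measured steps end at thiophen-2-yl and bear on this change: a 2.1-fold lower number from compound 1 to compound 3 (0.33 log units; beyond the scatter) (modest) and a 12-fold lower number from compound 2 to compound 3 (1.07 log units; beyond the scatter) (large). Neither involves a trifluoromethyl group, so the data fix the size only loosely, but a modest to large rise in this assay is expected on leaving thiophen-2-yl. The estimated change is a 5.3-fold higher number from compound 3 to compound 4 (0.73 log units; beyond the scatter) (an expectation only). Compound 4 is expected at 50 nM (range 12 nM to 250 nM).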

Compound 4, half-maximal inhibitory concentration: 270 nM
Compound 4: the middle estimate sits 5.4-fold (0.73 log units) below what was measured; the whole stated range lies below it.
By their numbers in this assay, from the lowest: compound 3; then compound 1; then compound 2; then compound 4.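

In this assay the change to 4-(trifluoromethyl)phenyl costs far more at this position than any earlier change suggested: it gives a 29-fold higher number from compound 3 to compound 4 (1.46 log units; beyond the scatter) from thiophen-2-yl and a 14-fold higher number from compound 1 to compound 4 (1.13 log units; beyond the scatter) from 3,4-dimethoxyphenyl. Even pyridin-4-yl, the weakest group until now, fares better, with a 2.5-fold higher number from compound 2 to compound 4 (0.39 log units; beyond the scatter) on this change, which leaves compound 4 the weakest of the four. Nothing measured here accounts for this result. As far as these compounds go, it remains open whether the loss belongs to the trifluoromethyl group or to the phenyl ring carrying it; an unsubstituted phenyl or a 4-methoxyphenyl at this place would separate the two.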